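Methoxy to Hydroxy: What Compound 3 Is Expected to Show

This account rests on a few compounds, and the source may have more. Where it says the series, first, only, none or still open, it means among the compounds named here.

Of the compounds shown here, two have been measured in a functional assay on RXF 393 cells (Homo sapiens) for inhibition, read by sulforhodamine B assay, with a stated time of 48 h; on this read-out higher numbers stand for weaker inhibition of growth and lower numbers for stronger inhibition of growth. Compound 1 `Cc1cc(O)cc(-c2nn(CC#N)cc2-c2ccnc(-c3ccc(Oc4ccccc4)cc3)c2)c1` gives 4310 nM in this assay, and compound 2 `COc1cc(C)cc(-c2nn(CC#N)cc2-c2ccnc(-c3ccc(N(C)C)cc3)c2)c1` gives 633 nM. Of the two numbers, compound 2 holds the lower one; the gap from compound 1 to compound 2 lies beyond the scatter. Among the compounds with values here, the two structures differ in more than one place, so no single step between measured compounds can be read from them; what they show is only the pair of values themselves.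

Compound 3 `Cc1cc(O)cc(-c2nn(CC#N)cc2-c2ccnc(-c3ccc(N(C)C)cc3)c2)c1` has not yet been measured. It is obtained from compound 2 by one change: hydrogen in place of methyl on an oxygen on an aromatic ring. In this assay, within the data shown here, the step from compound 2 to compound 3 is expected to be small, and may well fall within the scatter, with no measured step to anchor it in either direction; the expected step is a 1.3-fold higher number from compound 2 to compound 3 (0.13 log units; within the scatter). For compound 3 in this assay the estimate is 850 nM, within a range from 250 nM to 3000 nM.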

Compound 3, concentration for total growth inhibition: 61400 nM
For compound 3 the middle estimate is 72-fold (1.86 log units) below the measured one; measured number outside the range, above it.
By their numbers in this assay, from the lowest: compound 2; then compound 1; then compound 3.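

In this assay, the change from methoxy to hydroxy on the 3-methoxy-5-methylphenyl group turns out to be a large one, with a 97-fold higher number from compound 2 to compound 3 (1.99 log units; beyond the scatter), so the methyl on this oxygen makes a marked difference when dimethylamino is held constant. The other varied place matters as well: with hydroxy held constant, dimethylamino in place of phenoxy on an aromatic carbon gives a 14-fold higher number from compound 1 to compound 3 (1.15 log units; beyond the scatter), which separates an effect at this place from the mixed two-place comparison that the first pair offered. No available evidence bears on why either step is so large.

Going by these compounds, it remains open whether the methoxy to hydroxy step would be as large with phenoxy in place of dimethylamino, since only the dimethylamino pair gives this step. It is also open how far growth inhibition depends on the methyl itself, as the compounds shown do not tell whether an ethoxy group on the same aromatic carbon, or an amine in place of the oxygen, would stay near the number of compound 2 or move towards that of compound 3.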